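Swapping the Bromo-Methoxy Ring for a Second Methylsulfanyl Ring

The compounds below may be only part of what the source reports. "The series", "measured", "known", "first", "only" and "open" are said of these compounds alone.

Compound 1 `COc1ccc(C2=C(c3ccc(SC)cc3)CC3CCCN3C2=O)cc1Br` is the starting point. In a functional assay on A498 cells (Homo sapiens) for cytotoxicity (on this read-out lower numbers stand for stronger inhibition of growth and higher numbers for weaker inhibition of growth), compound 1 gives 600 nM, the lowest of the two numbers shown here. Its nearest neighbour is compound 2 `COc1ccc(C2=C(c3ccc(SC)cc3)CC3CCCN3C2=O)cc1`, which gives 800 nM; the step of a 1.3-fold higher number from compound 1 to compound 2 (0.12 log units; within the scatter) shows that removing the bromo group changes little. Compound 3 `CSc1ccc(C2=C(c3ccc(O)cc3)C(=O)N3CCCC3C2)cc1` reports only a limit, > 100000 nM. The steps of an at least 160-fold higher number from compound 1 to compound 3 (2.22 log units; beyond the scatter) and an at least 120-fold higher number from compound 2 to compound 3 (2.09 log units; beyond the scatter) show that a free hydroxyl in place of the methoxy group wipes out measurable growth inhibition.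

Compound 4 `CSc1ccc(C2=C(c3ccc(SC)cc3)C(=O)N3CCCC3C2)cc1` carries a different change at the same place: 4-(methylsulfanyl)phenyl in place of 3-bromo-4-methoxyphenyl on a double-bonded ring carbon. Unlike the move to compound 3, this keeps the oxygen-bearing methyl's role filled by a methylsulfanyl group and introduces no hydrogen-bond donor, while the loss of the bromo group matched that in a 1.3-fold higher number from compound 1 to compound 2 (0.12 log units; within the scatter). A modest weakening is therefore expected for compound 4, a 2.5-fold higher number from compound 1 to compound 4 (0.40 log units; beyond the scatter). The estimate for compound 4 is 1500 nM, with a likely range from 400 nM to 8000 nM.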

Compound 4, concentration for 50% growth inhibition: 15000 nM
Compound 4: middle estimate off by 10-fold (1.00 log units), on the low side, and the stated range ends below it.
By their numbers in this assay, from the lowest: compounds 1 and 2 (each within the scatter of the next); then compound 4. At a limit, above all of these: compound 3.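

At this place on the shared core, the swap of oxygen for sulfur is far from the quiet change that removing the bromo group was. In this assay, methylsulfanyl in place of methoxy alone gives a 19-fold higher number from compound 2 to compound 4 (1.27 log units; beyond the scatter), and the full change of ring gives a 25-fold higher number from compound 1 to compound 4 (1.40 log units; beyond the scatter), although neither the leaving nor the entering group has a hydrogen-bond donor. Methylsulfanyl still ranks ahead of hydroxy at this place, with an at least 6.6-fold lower number from compound 3 to compound 4 (0.82 log units; beyond the scatter), but that step rests on a limit and not on a number: the limit of > 100000 nM in this assay, at which 1 of the 4 values shown sits.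

The compounds shown leave open whether other groups here, such as ethoxy, an amine or fluoro, would behave like methoxy or like methylsulfanyl. Also open, as far as these compounds go, is whether a bromo group added to the 4-(methylsulfanyl)phenyl ring would change the result.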